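The compounds below may be only part of what the source reports. "The series", "measured", "known", "first", "only" and "open" are said of these compounds alone.

Measured compounds:
compound 1, `O=C(N/N=C/c1ccccc1O)c1ccc(-c2ccc(F)cc2)o1`, 40%
compound 2, `Cc1cccc(/C=N/NC(=O)c2ccc(-c3ccccc3[N+](=O)[O-])o2)c1`, 6.66%
compound 3, `COc1ccccc1/C=N/NC(=O)c1ccc(-c2ccc(F)cc2F)o1`, 53.1%

In a functional assay on Bel-7402 cells (Homo sapiens) for inhibition, read by sulforhodamine B assay, with a stated time of 48 h, tested at 10 uM (a higher number here means more inhibition of growth at the concentration tested, a lower number less inhibition of growth), compound 3 gives 53.1%, the highest of the three numbers in hand. The nearest of the other two is compound 1, whose 40% lies lower by a gap beyond the usual scatter, and the furthest is compound 2, whose 6.66% lies far lower, again beyond the scatter.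

Compound 4, `O=C(N/N=C/c1ccccc1O)c1ccc(-c2ccc(F)cc2F)o1`, has not yet been measured in this assay. It differs from compound 3 in one place: hydrogen in place of methyl on an oxygen on an aromatic ring. For the measured compounds named here, no pair of measured compounds shows exactly this change, so its size cannot be read off directly. Compound 1 carries the same hydroxy group as compound 4 but a different fluorine pattern on the other ring, and its value, taken against that of compound 3, only hints that the hydroxy compounds may sit somewhat lower. On this basis the step from compound 3 to compound 4 is expected to be small and downward, or none beyond the scatter, as a number 8.1 percentage points lower from compound 3 to compound 4 (within the scatter). Compound 4 is therefore estimated at 45%, with a range from 25% to 65%.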

Compound 4, percent growth inhibition at one concentration: 91.8%
Compound 4: middle estimate off by 46.8 percentage points, on the low side, outside the stated range (above it).
By their numbers in this assay, from the lowest: compound 2; then compound 1; then compound 3; then compound 4.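

In this assay, for the compounds shown here, the change from 2-methoxyphenyl to 2-hydroxyphenyl gives a number 38.7 percentage points higher from compound 3 to compound 4 (beyond the scatter), the first view of this change in a matched pair, and it shows that with the shared core held fixed, the methyl on this oxygen is not neutral: removing it leaves hydrogen on the oxygen and a large gain in growth inhibition. With the hydroxy group kept in place, fluoro in place of hydrogen on an aromatic carbon gives a number 51.8 percentage points higher from compound 1 to compound 4 (beyond the scatter), so this second single change is also large, and compound 4 stands above all three other compounds in this assay. Nothing in the available data accounts for either step.

The compounds shown leave open whether an ethyl group on the same oxygen, or an amine in place of the hydroxy group, would keep any of this inhibition. They also leave open whether the step from methoxy to hydroxy would be of similar size with the fluorine pattern of compound 1, since it is seen here in one pair only.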